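This account rests on a few compounds, and the source may have more. Where it says the series, first, only, none or still open, it means among the compounds named here.

Measured in an ADME assay on Vero cells (Chlorocebus sabaeus) for cytotoxicity, read by MTT assay, with a stated time of 48 h; on this read-out lower numbers stand for stronger inhibition and higher numbers for weaker inhibition:
compound 1, `Cc1cccc(C(=O)OC2CCC(CN3CCN(c4cc(=O)c5cc(C(F)(F)F)cc([N+](=O)[O-])c5s4)CC3)CC2)c1`: > 64 ug/mL.
compound 2, `O=C(NC1CCC(CN2CCN(c3cc(=O)c4cc(C(F)(F)F)cc([N+](=O)[O-])c4s3)CC2)CC1)c1ccccc1`: 44.3 ug/mL.
compound 3, `O=C(OC1CCC(CN2CCN(c3cc(=O)c4cc(C(F)(F)F)cc([N+](=O)[O-])c4s3)CC2)CC1)c1ccncc1`: > 64 ug/mL.

The result of compound 1 in this assay is a limit of the assay and not a number. The result of compound 3 in this assay is likewise a limit. Only compound 2 gives a number in this assay, and that number is 44.3 ug/mL. The measured steps are therefore poorly resolved: an at least 1.4-fold lower number from compound 1 to compound 2 (0.15 log units; that floor lies within the scatter), a step that the two limits leave unreadable from compound 1 to compound 3, and an at least 1.4-fold higher number from compound 2 to compound 3 (0.15 log units; that floor lies within the scatter). All three steps are shaped by the limit of > 64 ug/mL in this assay, at which 2 of the 3 values shown sit, so none of them shows a change beyond the scatter.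

Compound 4, `O=C(OC1CCC(CN2CCN(c3cc(=O)c4cc(C(F)(F)F)cc([N+](=O)[O-])c4s3)CC2)CC1)C1CCCCC1`, is a direct neighbour of compound 1, differing only in cyclohexyl in place of 3-methylphenyl on a carbonyl carbon. Among the compounds with values here, no measured step exchanges an aromatic ring for a saturated one at that carbonyl carbon; the nearest comparison, from compound 1 to compound 3, is unreadable. Given that compound 1 sits at the limit and that neither of the ester analogues gave a number, compound 4 is expected to show no step beyond the scatter, a number no higher from compound 1 to compound 4 (the limit leaves the size open). The estimate for compound 4 in this assay is 64 ug/mL, with a range from 32 ug/mL to 128 ug/mL, and most likely another limit.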

Compound 4, half-maximal inhibitory concentration: > 64 ug/mL
Compound 4 gave a limit, no number; the forecaster's own chance of this, stated with the estimate: 60%; the middle value sits exactly at the limit.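

Compound 4 shows that a non-aromatic ring on this carbonyl carbon, cyclohexyl, also leaves the result at a limit: in this assay compound 4 gives > 64 ug/mL, which is a limit of the assay and not a number. Within the data shown here, the steps from compound 1 and from compound 3 to compound 4 cannot be read, so the exchange of either aromatic ring for cyclohexyl has no size here, and the one step that can be stated is an at least 1.4-fold higher number from compound 2 to compound 4 (0.15 log units; that floor lies within the scatter). Compound 1, compound 3 and compound 4 now all end at the same limit, and compound 2 alone gives a number, yet no step among the four goes beyond the scatter, and the series remains bounded by one value: the limit of > 64 ug/mL in this assay, at which 3 of the 4 values shown sit.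

Going by these compounds, whether a carboxylic acid or a primary amine in place of cyclohexyl on this carbonyl carbon would give a number in this assay stays open. Also open, on these data alone, is whether an amide carrying cyclohexyl, as the counterpart of the benzamido group of compound 2, would give a number at all.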